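A few compounds are considered here, and "the series" means these few. Any claim that something is new, unique, unknown or untested is made for them only; others in the source may bear on it.

Measured in a functional assay on MOLT-4 cells (Homo sapiens) for inhibition, read by MTT assay, with a stated time of 72 h; a higher number here means a weaker inhibitor, a lower number a stronger inhibitor:
- Compound 1 `COc1cc(NC(C)CCCNC(=O)NNC(=O)Nc2ccc(F)cc2)c2ncccc2c1`: >= 250000 nM, which is a limit of the assay and not a number.
- Compound 2 `COc1cc(NC(C)CCCNC(=O)Nc2ccc(F)cc2)c2ncccc2c1`: 24000 nM
- Compound 3 `COc1cc(NC(C)CCCNC(=O)NNC(=O)Nc2ccc(Br)cc2)c2ncccc2c1`: 209000 nM

Of the two true numbers, compound 3 holds the higher one, so it is the weaker inhibitor of that pair: an 8.7-fold higher number from compound 2 to compound 3 (0.94 log units; beyond the scatter). Compound 4 `COc1cc(NC(C)CCCNC(=O)Nc2cccc(O)c2)c2ncccc2c1` differs from it as follows: 3-hydroxyphenyl in place of ((4-bromophenyl)carbamoyl)amino on an amide-type nitrogen. In words, 3-hydroxyphenyl replaces ((4-bromophenyl)carbamoyl)amino on an amide-type nitrogen. This leaves compound 4 with a ring placed directly on that nitrogen, as in compound 2.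

Going by the values given here, the closest precedent is the same kind of shortening, which was large: an at least 10-fold lower number from compound 1 to compound 2 (1.01 log units; beyond the scatter). The swap of bromo for fluoro tells little: an at least 1.1-fold lower number from compound 1 to compound 3 (0.07 log units; that floor lies within the scatter). Among the compounds with values here, no measured compound carries a 3-hydroxyphenyl group, and the range must stay wide. A clear drop in this assay is expected, close in size to the gap separating compound 2 from compound 3. The expected step is a 7.0-fold lower number from compound 3 to compound 4 (0.84 log units; beyond the scatter). For compound 4 the estimated value is 30000 nM, with an expected range from 9000 nM to 100000 nM.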

Compound 4, half-maximal inhibitory concentration: 24000 nM
Beside the measured number, compound 4's estimate is 1.3-fold (0.10 log units) above it; the range from low to high includes it.
By their numbers in this assay, from the lowest: compounds 2 and 4 (each within the scatter of the next); then compound 3. At a limit, above all of these: compound 1.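

In this assay, replacing ((4-bromophenyl)carbamoyl)amino with 3-hydroxyphenyl gives an 8.7-fold lower number from compound 3 to compound 4 (0.94 log units; beyond the scatter), so the gain seen earlier when a ring was placed directly on the amide-type nitrogen also appears with a different ring. The choice between these two rings shows no effect here, with no change at the digits printed from compound 2 to compound 4 (within the scatter), so 4-fluorophenyl and 3-hydroxyphenyl cannot be told apart in this assay. The comparison with compound 1 gives an at least 10-fold lower number from compound 1 to compound 4 (1.01 log units; beyond the scatter), which is only a floor, since compound 1 stands at a limit and not at a true number: the limit of >= 250000 nM in this assay, at which 1 of the 4 values shown sits.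

On these data alone, both compounds with the ring directly on that nitrogen carry an aromatic ring, so it remains open whether a cyclohexyl ring, or a ring bearing an amine or a carboxylic acid, would give a similar value. As far as these compounds go, it is also open how a longer chain joining the shared core to this nitrogen would change the number.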